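The source may report more compounds than this note shows. Statements on the series, on what has been measured and on what is new or still open speak of the compounds shown alone.

Measured so far:
compound 1, `O=C(Nc1cccc(-c2ccoc2)c1)C(Cl)Cl`: 8480 nM
compound 2, `O=C(Nc1cccc(-c2cccc(F)c2)c1)C(Cl)Cl`: 9530 nM

In a functional assay on A549 cells (Homo sapiens) for cytotoxicity, read by MTT assay, with a stated time of 68 h (a lower number here means a stronger inhibitor, a higher number a weaker inhibitor), compound 1 gives 8480 nM, and compound 2 gives 9530 nM. Compound 2 has the higher of these two numbers, yet the gap to compound 1 is within the usual scatter of repeated measurements, so the two compounds cannot be told apart on these data. The next compound, compound 3 `O=C(Nc1cccc(-c2cccc(Cl)c2)c1)C(Cl)Cl`, differs from compound 2 in one place: chloro in place of fluoro on an aromatic carbon. Among the compounds with values here, with only two measured compounds and no comparable step between them, there is nothing to anchor the size of this change, so the expectation is a step of no more than the scatter, if anything toward a slightly lower number. The expected step from compound 2 to compound 3 in this assay is a 1.3-fold lower number from compound 2 to compound 3 (0.10 log units; within the scatter). Compound 3 is therefore estimated at 7500 nM, with a range from 3000 nM to 20000 nM.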

Compound 3, half-maximal inhibitory concentration: 21400 nM
For compound 3 the middle estimate is 2.9-fold (0.46 log units) below the measured one, and the stated range ends below it.
By their numbers in this assay, from the lowest: compounds 1 and 2 (each within the scatter of the next); then compound 3.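

In this assay, the carbon meta to a large group on the six-membered aromatic ring responds to which halogen it carries: chloro in place of fluoro gives a 2.2-fold higher number from compound 2 to compound 3 (0.35 log units; beyond the scatter). This modest step lies beyond the scatter and runs toward a weaker inhibitor, so exchanging one heavy atom for another, with no change in hydrogen-bond donors, acceptors or net charge, is enough to register in this assay. Nothing measured here accounts for the step.

The compounds shown leave open how this place would respond to other groups, such as a methoxy group, a nitrile or an amine. They also leave open whether the same exchange elsewhere on this ring would give a step of similar size and direction.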